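Spirocyclic pyrazolone series: para-halogen on the N-phenyl ring

This account rests on a few compounds, and the source may have more. Where it says the series, first, only, none or still open, it means among the compounds named here.

Measured compounds in a functional assay on MDA-MB-231 cells (Homo sapiens) for antiproliferative activity, read by CCK-8 assay, with a stated time of 72 h; on this read-out higher numbers stand for weaker inhibition and lower numbers for stronger inhibition:
compound 1 `CC1=NN(c2ccccc2)C(=O)C12C=CC(=O)C=C2c1cccc(C)c1` — 85800 nM
compound 2 `CC1=NN(c2ccc(Br)cc2)C(=O)C12C=CC(=O)C=C2c1ccc(C)cc1` — 15900 nM
compound 3 `CC1=NN(c2ccccc2)C(=O)C12C=CC(=O)C=C2c1ccccc1` — 27400 nM

Compound 3 has the second highest number of the three. Going by the values given here, its only single-point neighbour is compound 1, and the step of a 3.1-fold lower number from compound 1 to compound 3 (0.50 log units; beyond the scatter) is a change at the other aryl group, not at the phenyl on nitrogen. Compound 2 differs from compound 3 in two places, so no step is shown for that pair; its value and that of compound 3 lie within the scatter of each other.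

Compound 4 `CC1=NN(c2ccc(Cl)cc2)C(=O)C12C=CC(=O)C=C2c1ccccc1` carries chloro in place of hydrogen on an aromatic carbon on the phenyl attached to nitrogen. Among the compounds with values here, no measured step isolates a substituent at this place; compound 2 is the only hint that a para-halogen on this ring is tolerated. The expected outcome is therefore a small step at most, a 1.5-fold lower number from compound 3 to compound 4 (0.18 log units; within the scatter), toward a somewhat lower number or none beyond the scatter. Compound 4 is estimated at 18000 nM, with a range from 7000 nM to 45000 nM.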

Compound 4, half-maximal inhibitory concentration: > 100000 nM
Compound 4 was reported as a limit (the forecaster's own chance of this, stated with the estimate: 5%); middle value at least 5.5-fold (0.74 log units) away from the limit.
By their numbers in this assay, from the lowest: compounds 2 and 3 (each within the scatter of the next); then compound 1. At a limit, above all of these: compound 4.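

In this assay, going by these compounds alone, the change from phenyl to 4-chlorophenyl gives an at least 3.6-fold higher number from compound 3 to compound 4 (0.56 log units; beyond the scatter) and is the first single change measured on the phenyl attached to nitrogen. From the compounds shown here alone, this place is therefore not indifferent to substitution: chloro on this aromatic carbon, para to a large group, is enough to move the read-out beyond the scatter, and the true size of the step stays unknown. Compound 4 stands at a limit of the assay and not at a number: the limit of > 100000 nM in this assay, at which 1 of the 4 values shown sits.

Compound 2, with 4-bromophenyl on nitrogen, gives 15900 nM but differs from compound 4 in two places, so these two compounds cannot be read against each other. Going by these compounds, how a methoxy group, an amine or a carboxylic acid would behave at this place remains open, as does whether fluoro would follow chloro.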